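Fluoro for Methyl on a Limit-Bound Starting Point

The compounds below may be only part of what the source reports. "The series", "measured", "known", "first", "only" and "open" are said of these compounds alone.

Of the compounds shown here, two have been measured in an assay for inhibition of protein disulfide-isomerase (Homo sapiens), with a stated time of 1 h; a higher number here means a weaker inhibitor, a lower number a stronger inhibitor. Compound 1 `Oc1ccc2ccncc2c1C(c1ccc(F)cc1)N1CCCCC1` gives 10200 nM in this assay. Compound 2 `Cc1ccnc(NC(c2ccccc2C)c2ccc3cccnc3c2O)c1` gives only a limit in this assay, > 40000 nM; that reading is a limit of the measurement and not a number, so compound 2 stands at the edge of what this assay reports (the limit of > 40000 nM in this assay, at which 1 of the 2 values shown sits). Compound 3 `Cc1ccnc(NC(c2ccccc2F)c2ccc3cccnc3c2O)c1` has not yet been measured in this assay. It differs from compound 2 in one place (fluoro in place of methyl on an aromatic carbon). Between the two measured compounds no single-point step exists, so nothing shown here connects a change of this kind to a movement in this assay. The account therefore expects no step beyond the usual scatter, in either direction, from compound 2 to compound 3 in this assay; a small shift cannot be excluded, but since the starting point is a limit, the most likely outcome is again a limit. Compound 3 is accordingly estimated at 40000 nM, with a range from 15000 nM to 120000 nM, and the expected step is a number no higher from compound 2 to compound 3 (the limit leaves the size open).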

Compound 3, half-maximal inhibitory concentration: 880 nM
For compound 3 the middle estimate is 45-fold (1.66 log units) above the measured one; measured number below the stated range.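

In this assay, the exchange of methyl for fluoro on an aromatic carbon, ortho to a large group, produces an at least 45-fold lower number from compound 2 to compound 3 (1.65 log units; beyond the scatter) through the change from 2-methylphenyl to 2-fluorophenyl alone. Among these compounds, this is the first sign that this position governs the read-out, since the two earlier compounds offered no single-point step, and here one heavy atom is replaced by one heavy atom, with no ring, hydrogen-bond donor, hydrogen-bond acceptor or net charge entering or leaving. Compound 2 stands at a limit of the assay and not at a number, so the step has a lower bound but no known full size: the limit of > 40000 nM in this assay, at which 1 of the 3 values shown sits.

The compounds shown do not separate what fluoro adds from what the loss of methyl removes, and they do not say why this exchange moves the read-out so far. Going by these compounds, whether chloro, methoxy or plain hydrogen at the same place would match compound 3, which gives 880 nM in this assay, also remains open, as does whether fluoro would have the same effect at another carbon of that ring.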